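The compounds below may be only part of what the source reports. "The series", "measured", "known", "first", "only" and "open" are said of these compounds alone.

Measured compounds:
Compound 1, `COc1ccc(/C=C/C=C/C(=O)c2ccccc2O)cc1`: 40%
Compound 2, `COc1ccc(/C=C/C=C/C(=O)c2c(O)cccc2OC)cc1OC`: 40%
Compound 3, `COc1ccc(/C=C/C=C/C(=O)c2cc(F)ccc2O)cc1`: "not active" (no number reported)

In an in vitro assay on cells for inhibition of Amine oxidase [flavin-containing] A (Homo sapiens), read by Amplex Red, with a stated time of 15 min, tested at 100 uM (on this read-out higher numbers stand for more inhibition at the one concentration tested (going by the name of the read-out) and lower numbers for less inhibition), compound 1 gives 40%. Compound 2 gives 40% in this assay, so compound 1 sits level with compound 2 at the digits shown, the two numbers lying within the usual scatter of each other. Compound 3 is reported as "not active" (no number reported) in this assay, without a number, so nothing more can be said of its size.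

The new compound is compound 4, `COc1ccc(/C=C/C(O)=C/C(=O)c2ccccc2O)cc1`. It differs from compound 1 by one change: hydroxy in place of hydrogen on a double-bonded chain carbon bound to two double-bonded chain carbons. For the measured compounds named here, no measured pair shows a change of just this kind, so there is no directly comparable step to lean on. The two compounds with numbers sit at the same level despite differences on the rings, which gives no sign that small changes move this read-out much. On that basis the step from compound 1 to compound 4 is expected to be no larger than the scatter, and compound 4 is estimated at 35%, with a range from 10% to 60%, meaning an expected step of a number 5 percentage points lower from compound 1 to compound 4 (within the scatter) in this assay.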

Compound 4, a percentage reported as inhibition, at one concentration (the size of the read-out at that concentration, not a potency): "not active" (no number reported)
Compound 4 has no reported number here, and the estimate cannot be compared.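

In this assay, for the compounds shown here, compound 4 carries no reported number, so no step from compound 1 to compound 4 can be read. No measured evidence bears on this result. The compounds shown leave open how much, if at all, the added hydroxy changes inhibition.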